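Sulfonyl chain extension in the legumain nitrile series

The compounds below may be only part of what the source reports. "The series", "measured", "known", "first", "only" and "open" are said of these compounds alone.

Compound 1 `CCS(=O)(=O)N(Cc1ccc(-c2cccc(F)c2)cc1)[C@@H](C)C(=O)N[C@H](C#N)CC(N)=O` gives 3890 nM in an assay on isolated protein for inhibition of legumain (Homo sapiens), with stated times of 2 min and 60 min (a higher number here means a weaker inhibitor, a lower number a stronger inhibitor), the lowest of the two numbers obtained there, though compound 3 `CCC[C@@H](C(=O)N[C@H](C#N)CC(N)=O)N(Cc1ccc(-c2cccc(F)c2F)cc1)S(C)(=O)=O`, which gives 7750 nM in this assay, sits within the scatter of it. Compound 2 `C[C@@H](C(=O)N[C@H](C#N)CC(N)=O)N(Cc1ccc(-c2cccc(F)c2F)cc1)S(=O)(=O)c1ccccc1` reaches only a limit of this assay, > 10000 nM. The series thus includes (the limit of > 10000 nM in this assay, at which 1 of the 3 values shown sits).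

Compound 4 `CCCS(=O)(=O)N(Cc1ccc(-c2cccc(F)c2)cc1)[C@@H](C)C(=O)N[C@H](C#N)CC(N)=O` differs from compound 1 by methyl in place of hydrogen on a saturated chain carbon, two bonds along the chain from a sulfonyl sulfur. Within the data shown here, no measured pair shows this change on its own. The expected step is a 1.1-fold lower number from compound 1 to compound 4 (0.05 log units; within the scatter), not beyond the scatter in either direction. Compound 4 is therefore estimated at 3500 nM in this assay, with a range from 1500 nM to 8500 nM.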

Compound 4, half-maximal inhibitory concentration: > 10000 nM
Compound 4: a limit, no number; the forecaster's own chance of this, stated with the estimate: 10%; at least 2.8-fold (0.45 log units) between middle value and limit.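

In this assay, among these compounds, going from ethylsulfonyl to propylsulfonyl gives an at least 2.5-fold higher number from compound 1 to compound 4 (0.41 log units; beyond the scatter), so this chain carbon is sensitive to a single added methyl, a point the earlier compounds, which differ in more than one place, could not show. Compound 4 gives a limit, not a number, so the full size of the step stays unknown, and such limits now form a large share of the series: the limit of > 10000 nM in this assay, at which 2 of the 4 values shown sit.

Open, from the compounds shown here alone, is whether a hydroxyl or an amine on this carbon would give a different result from methyl. Also open, going by these compounds, is how a cyclopropylsulfonyl group would compare on the core of compound 1.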